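Swapping propanoyl for ethoxycarbonyl on a shared core

The source may hold more compounds than are shown below. What is called first, only, known or untested is meant among the compounds shown, and "the series" means these compounds.

Of the compounds shown here, three have been measured so far in a physicochemical assay for solubility, read by HPLC, in phosphate buffer, measured as kinetic solubility, at pH 7.4 (a lower number here means a less soluble compound, a higher number a more soluble compound), and they do not sit level. Compound 3 `CCC(=O)c1cc(-c2ccc(F)cc2)n(-c2ccc(S(N)(=O)=O)cc2)c1` gives 63000 nM as the highest of the three numbers, and its gaps to the other two lie beyond the usual scatter. In this assay compound 1 `CCOC(=O)c1cc(-c2ccc(F)cc2)n(-c2ccc(S(N)(=O)=O)cc2)c1C` gives 12600 nM and compound 2 `CCOC(=O)c1cc(-c2ccc(Cl)cc2)n(-c2ccc(S(N)(=O)=O)cc2)c1` gives 10800 nM on the same scale.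

Next comes compound 4 `CCOC(=O)c1cc(-c2ccc(F)cc2)n(-c2ccc(S(N)(=O)=O)cc2)c1` with ethoxy in place of ethyl on a carbonyl carbon so that propanoyl becomes ethoxycarbonyl. Among the measured compounds shown here, no measured pair shows this change on its own. The closest guide is that compound 1 at 12600 nM and compound 2 at 10800 nM also carry ethoxycarbonyl, although each differs from compound 4 elsewhere. The expected change is a step of a 3.9-fold lower number from compound 3 to compound 4 (0.60 log units; beyond the scatter) that is estimated to run toward a lower number, beyond the scatter. Compound 4 is estimated at 16000 nM and is expected to fall from 7000 nM to 35000 nM in most repeat measurements.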

Compound 4, solubility: 36400 nM
Compound 4: the middle estimate sits 2.3-fold (0.36 log units) below what was measured; the whole stated range lies below it.
By their numbers in this assay, from the lowest: compounds 2 and 1 (each within the scatter of the next); then compounds 4 and 3 (each within the scatter of the next).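

In this assay, the change from propanoyl to ethoxycarbonyl gives a 1.7-fold lower number from compound 3 to compound 4 (0.24 log units; within the scatter) and so cannot be told apart from repeat scatter, which means that ethoxy in place of ethyl on this carbonyl carbon shows no clear effect on the number in this pair. The larger differences appear elsewhere on the shared core: fluoro in place of chloro on an aromatic carbon gives a 3.4-fold higher number from compound 2 to compound 4 (0.53 log units; beyond the scatter) and hydrogen in place of methyl on an aromatic carbon gives a 2.9-fold higher number from compound 1 to compound 4 (0.46 log units; beyond the scatter) as modest steps beyond the scatter. No outside measurement is available to explain any of these steps.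

On these data alone, it remains open whether an amide, a carboxylic acid or a longer chain on the same carbonyl carbon would stay level with ethyl and ethoxy. The chloro and methyl steps are also untested with propanoyl in place of ethoxycarbonyl.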